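The compounds below may be only part of what the source reports. "The series", "measured", "known", "first", "only" and "open" are said of these compounds alone.

Measured compounds:
Compound 1, `COc1ccc(/C=C\C(=O)O)c(OCc2cn(-c3ccccc3C(=O)N3CCC(O)C3)nn2)c1CC=C(C)C`: 32000 nM
Compound 2, `COc1ccc(/C=C\C(=O)O)c(OCc2cn(-c3cccc([N+](=O)[O-])c3)nn2)c1CC=C(C)C`: 27300 nM

In a functional assay on HCT-116 cells (Homo sapiens) for cytotoxicity, read by MTT assay, with a stated time of 24 h (a lower number here means a stronger inhibitor, a higher number a weaker inhibitor), compound 1 gives 32000 nM and compound 2 gives 27300 nM. Compound 2 carries the lower of the two numbers, but the gap to compound 1 falls within the usual scatter, so the two compounds cannot be told apart on these data. Both sit at weak cytotoxicity.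

Compound 3, `COc1ccc(/C=C\C(=O)O)c(OCc2cn(-c3ccc(CO)cc3)nn2)c1CC=C(C)C`, has not yet been measured in this assay. It differs from compound 2 in one place: 4-(hydroxymethyl)phenyl in place of 3-nitrophenyl on an aromatic nitrogen. Among the compounds with values here, no step between measured compounds bears on this exchange. With compound 1 and compound 2 carrying different groups at the same ring nitrogen and returning numbers within the scatter of each other, no movement beyond the scatter is expected here. The step from compound 2 to compound 3 is estimated at a 1.1-fold higher number from compound 2 to compound 3 (0.04 log units; within the scatter). Compound 3 is expected to give about 30000 nM in this assay, within a range of 12000 nM to 75000 nM.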

Compound 3, half-maximal inhibitory concentration: 31700 nM
For compound 3 the middle estimate is 1.1-fold (0.02 log units) below the measured one, and the stated range covers the measured number.
By their numbers in this assay, from the lowest: compounds 2, 3 and 1 (each within the scatter of the next).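

In this assay the exchange of 3-nitrophenyl for 4-(hydroxymethyl)phenyl on the aromatic nitrogen of the five-membered ring gives a 1.2-fold higher number from compound 2 to compound 3 (0.06 log units; within the scatter) and is the only step shown that differs in one place. At this position, a phenyl ring carrying a nitro group and one carrying a hydroxymethyl group therefore cannot be told apart, although the substituent and its place on the ring both differ. Nothing measured here explains this result.

As far as these compounds go, all three compounds carry a phenyl ring on this nitrogen, so it remains open whether a plain alkyl chain there, or a phenyl ring bearing an amine, would give a number beyond the scatter. The compounds shown also leave open what a methyl ester in place of the carboxylic acid on the shared core would give.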